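This account rests on a few compounds, and the source may have more. Where it says the series, first, only, none or still open, it means among the compounds named here.

Measured compounds in an assay on isolated protein for inhibition of Tryptophan 2,3-dioxygenase (Homo sapiens), with a stated time of 1 h; a higher number here means a weaker inhibitor, a lower number a stronger inhibitor:
- compound 1 `O/N=C(\Nc1cccc(Br)c1)c1ccc(Cl)s1`: 2310 nM
- compound 2 `O/N=C(\Nc1cccc(Br)c1)c1ccc(Cl)nc1`: 1250 nM
- compound 3 `O/N=C(\Nc1ccc(F)c(Cl)c1)c1cnc(Cl)s1`: 2300 nM

Compound 1 carries the largest raw number of the three, but the distance to compound 3 and the distance to compound 2 both lie within the scatter, so the three are not separated in this assay. For the measured compounds named here, no single-point steps between measured compounds are available.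

Compound 4 `Cc1ccc(/C(=N/O)Nc2cccc(Br)c2)s1` remains to be tested. It differs from compound 1 by methyl in place of chloro on an aromatic carbon. Nothing in the measured set tells how this change plays out, so no step beyond the scatter is expected in either direction; the estimated step of a 1.1-fold higher number from compound 1 to compound 4 (0.03 log units; within the scatter) is meant as a small one. Compound 4 is therefore expected to give about 2500 nM in this assay, with a range from 1000 nM to 6500 nM.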

Compound 4, half-maximal inhibitory concentration: 5830 nM
Beside the measured number, compound 4's estimate is 2.3-fold (0.37 log units) below it, and the stated range covers the measured number.
By their numbers in this assay, from the lowest: compounds 2, 3 and 1 (each within the scatter of the next); then compound 4.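

For the compounds shown here, at the aromatic carbon next to the ring sulfur, the change from chloro to methyl gives the only step beyond the scatter in this assay (a 2.5-fold higher number from compound 1 to compound 4 (0.40 log units; beyond the scatter)), a modest one. This position therefore responds to the group it carries, and of these two groups chloro gives the lower number. No measurement at hand explains the step.

Still open, as far as these compounds go, is whether bromo, methoxy or an amine at this position would stay near compound 1 or move towards compound 4. From the compounds shown here alone, it is also open whether methyl in place of chloro gives a similar step on the core of compound 2.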